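Enlarging the Ether on a Shared Core

This account rests on a few compounds, and the source may have more. Where it says the series, first, only, none or still open, it means among the compounds named here.

In a functional assay on MCF7 cells (Homo sapiens) for inhibition, with a stated time of 48 h (on this read-out higher numbers stand for weaker inhibition and lower numbers for stronger inhibition), compound 1 (`COc1cc(Sc2c[nH]c3ccc([N+](=O)[O-])cc23)cc(OC)c1OC`) gives 560 nM and compound 2 (`COc1cc(Sc2c[nH]c3ccc(OC(C)C)cc23)cc(OC)c1OC`) gives 1500 nM as the higher of the two numbers. Compound 3 (`COc1cc(Sc2c[nH]c3ccc(OCCOCc4ccccc4)cc23)cc(OC)c1OC`) has not yet been measured. It carries 2-(benzyloxy)ethyl in place of isopropyl on an oxygen on an aromatic ring. Going by the values given here, only one measured step changes this part of the shared core (a 2.7-fold higher number from compound 1 to compound 2 (0.43 log units; beyond the scatter)), and it was modest. A step of similar modest size toward a higher number is therefore expected in this assay (a 1.3-fold higher number from compound 2 to compound 3 (0.12 log units; within the scatter)), though a single step is thin evidence. For compound 3 the estimated value is 2000 nM (expected range 500 nM to 8000 nM).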

Compound 3, half-maximal inhibitory concentration: 260 nM
For compound 3 the middle estimate is 7.7-fold (0.89 log units) above the measured one; measured number below the stated range.
By their numbers in this assay, from the lowest: compound 3; then compound 1; then compound 2.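

In this assay, a much larger ether at this position does not weaken inhibition: 2-(benzyloxy)ethyl in place of isopropyl, bringing one six-membered aromatic ring and one hydrogen-bond acceptor, gives a 5.8-fold lower number from compound 2 to compound 3 (0.76 log units; beyond the scatter) on the shared core. The enlarged ether also passes the nitro compound, with a 2.2-fold lower number from compound 1 to compound 3 (0.33 log units; beyond the scatter), so among these compounds the lowest number does not belong to the nitro group. Nothing measured here explains this drop.

Still open, as far as these compounds go, is which part of the new group matters: its aromatic ring, its chain oxygen or its length. A 2-methoxyethyl ether, which keeps the chain oxygen without the aromatic ring, would begin to separate these.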